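1,3-Benzothiazol-2-yl replaces 1,2,3,4-tetrahydroisoquinolin-3-yl in compound 1

The source may report more compounds than this note shows. Statements on the series, on what has been measured and on what is new or still open speak of the compounds shown alone.

- compound 1 `c1ccc2c(c1)CN[C@H](CN(CCCN1CCNCC1)[C@H]1CCCc3cccnc31)C2` gives 88%
- compound 2 `CC(C)N1CCN(CCCN(C[C@H]2Cc3ccccc3CN2)[C@H]2CCCc3cccnc32)CC1` gives 4%

Both numbers come from an ADME assay on microsomes from liver (Rattus norvegicus) for metabolic stability, read by LC-MS, with a stated time of 10 min, tested at 0.5 uM (a lower number here means that less of the compound is left, a higher number that more of the compound is left), and compound 1 holds the higher of the two, with compound 2 lower by far more than the usual scatter of repeat measurements. Compound 3 `c1cnc2c(c1)CCC[C@@H]2N(CCCN1CCNCC1)Cc1nc2ccccc2s1` has not yet been measured. The change from compound 1 is 1,3-benzothiazol-2-yl in place of 1,2,3,4-tetrahydroisoquinolin-3-yl on a saturated chain carbon bound to an amine nitrogen and it sits on a saturated chain carbon bound to an amine nitrogen. For the measured compounds named here, no measured pair shows a single change, and the size of the step rests on judgement. From compound 1 at 88% there is little room upward in this assay and a moderate fall, beyond the scatter, is expected. The estimated step is a number 20 percentage points lower from compound 1 to compound 3 (beyond the scatter) in the downward direction. Compound 3 is estimated at 68% with an expected range from 35% to 90% until a measurement is available.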

Compound 3, percent of the compound remaining: 21%
Beside the measured number, compound 3's estimate is 47 percentage points above it; the whole stated range lies above it.
By their numbers in this assay, from the lowest: compound 2; then compound 3; then compound 1.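

In this assay, 1,3-benzothiazol-2-yl in place of 1,2,3,4-tetrahydroisoquinolin-3-yl on a saturated chain carbon bound to an amine nitrogen gives a number 67 percentage points lower from compound 1 to compound 3 (beyond the scatter), so the read-out of this series depends strongly on what this place carries. The change removes a hydrogen-bond donor and a defined stereocentre and brings in sulfur, all in one step, so this pair cannot separate these differences. Nothing at hand explains the size of the fall.

The compounds shown leave open whether other groups at this place, such as a benzylamine, a phenyl or a 1,3-benzoxazol-2-yl, would stand nearer compound 1 or compound 3 in this assay. They also leave open whether the same exchange would give a step of this size on a different remainder of the molecule.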